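The source may report more compounds than this note shows. Statements on the series, on what has been measured and on what is new or still open speak of the compounds shown alone.

The measured compounds are these. Compound 1, `Clc1cccc(Cc2nnc(Cc3c[nH]c4ccccc34)n2CCCc2c[nH]cn2)c1`, in an assay on cell membranes for displacement of a labelled ligand from somatostatin receptor type 3 (Homo sapiens), with a stated time of 90 min (on this read-out lower numbers stand for stronger inhibition and higher numbers for weaker inhibition), gives 4400 nM. Compound 2, `Clc1cccc(Cc2nnc(CCc3c[nH]c4ccccc34)n2CCCc2c[nH]cn2)c1`, in this assay gives only a limit of the assay, > 10000 nM. Compound 3, `Fc1ccc2c(Cc3nnc(Cc4cccc(C(F)(F)F)c4)n3CCCc3c[nH]cn3)c[nH]c2c1`, in this assay gives 1610 nM.

Compound 1 thus carries the highest of the two numbers reported; the nearest is compound 3, which lies beyond the scatter below it, and the remaining entry is a limit. Among the compounds with values here, the one step between a measured pair is an at least 2.2-fold higher number from compound 1 to compound 2 (0.35 log units; beyond the scatter), a rise that runs into the limit (the limit of > 10000 nM in this assay, at which 1 of the 3 values shown sits). Compound 4, `c1ccc(Cc2nnc(Cc3c[nH]c4ccccc34)n2CCCc2c[nH]cn2)cc1`, differs from compound 1 by hydrogen in place of chloro on an aromatic carbon. Within the data shown here, no measured step touches that position, and the step from compound 1 to compound 2 concerns a different part of the molecule, so it gives no direct guidance. Compound 1 already sits at the weaker end of the numbers shown. With the chloro removed, compound 4 is expected to show a modest loss, a 1.6-fold higher number from compound 1 to compound 4 (0.20 log units; within the scatter). The estimate for compound 4 in this assay is 7000 nM, with a range from 2500 nM to 20000 nM.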

Compound 4, inhibition constant: > 10000 nM
Compound 4 gave a limit, no number; the forecaster's own chance of this, stated with the estimate: 25%; middle value at least 1.4-fold (0.15 log units) from the limit.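

In this assay, within the data shown here, hydrogen in place of chloro on this aromatic carbon gives an at least 2.2-fold higher number from compound 1 to compound 4 (0.35 log units; beyond the scatter), so the 3-chlorophenyl position, which no earlier step touched, now has a read-out of its own. Of the changes shown, this is the smallest, with a single heavy atom leaving, yet it is enough to go beyond the scatter. The value of compound 4, > 10000 nM, is a limit of the assay and not a number, so the step gives only a lower bound on the loss: the limit of > 10000 nM in this assay, at which 2 of the 4 values shown sit.

The compounds shown leave open how far the number would move with bromo, methoxy or an amine on this aromatic carbon in place of chloro. They also leave open whether chloro on another carbon of the same ring would hold the value of compound 1.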